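Swapping a Methoxy for an Amino on an Inactive Scaffold

The compounds below may be only part of what the source reports. "The series", "measured", "known", "first", "only" and "open" are said of these compounds alone.

In a functional assay on MCF7 cells (Homo sapiens) for cytotoxicity, read by MTT assay, with a stated time of 48 h (on this read-out higher numbers stand for weaker inhibition and lower numbers for stronger inhibition), compound 1 `COc1ccc(-c2cn(C(=O)Nc3cc(OC)c(OC)c(OC)c3)c(=O)n2-c2cc(OC)c(OC)c(OC)c2)cc1` gives > 50000 nM, which is a limit of the assay and not a number. Compound 2 `COc1ccc(-c2cn(C(=O)Nc3cc(OC)c(OC)c(OC)c3)c(=O)n2-c2cc(OC)c(OC)c(OC)c2)cc1OC` gives > 50000 nM, and this too is only a limit. Compound 2 therefore has no exact value to serve as a starting point.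

Compound 3 `COc1ccc(-c2cn(C(=O)Nc3cc(OC)c(OC)c(OC)c3)c(=O)n2-c2cc(OC)c(OC)c(OC)c2)cc1N` differs from compound 2 at a single place: amino in place of methoxy on an aromatic carbon. This is amino in place of methoxy on an aromatic carbon, turning 3,4-dimethoxyphenyl into 3-amino-4-methoxyphenyl.

Going by the values given here, only one measured step bears on this change, the one that put the methoxy on that same carbon, and it offers no size to carry over: a step that the two limits leave unreadable from compound 1 to compound 2. The expectation is therefore loose. A further limit in this assay is quite possible, and any readable number would show stronger inhibition than the limits seen so far. The expected change is an at least 1.6-fold lower number from compound 2 to compound 3 (0.22 log units; that floor lies within the scatter), a cautious estimate leaning toward stronger inhibition. Compound 3 is estimated at 30000 nM, with an expected range from 3000 nM to 60000 nM.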

Compound 3, half-maximal inhibitory concentration: > 50000 nM
Compound 3 gave a limit, no number; the forecaster's own chance of this, stated with the estimate: 55%; middle value at least 1.6-fold (0.22 log units) from the limit.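

Compound 1, compound 2 and compound 3 all stop at the same assay limit, so none of the steps between them can be read: the limit of > 50000 nM in this assay, at which 3 of the 3 values shown sit.

The compounds shown leave open how hydrogen, methoxy and amino on this aromatic carbon rank against one another, and whether any change to the shared core gives a readable number in this assay at all.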